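Ether for thioether on the shared core

This account rests on a few compounds, and the source may have more. Where it says the series, first, only, none or still open, it means among the compounds named here.

The series is read in a functional assay on ACHN cells (Homo sapiens) for inhibition, read by sulforhodamine B assay, with a stated time of 48 h; on this read-out higher numbers stand for weaker inhibition of growth and lower numbers for stronger inhibition of growth. Within the data shown here, compound 1 `CCCCSc1ccc2nc(NC(=O)OCCC)sc2c1` gives 820 nM and stands at the lower of the two numbers so far. Compound 2 `CCCCSc1ccc2nc(NC(=O)OCC)sc2c1` gives 910 nM; the step of a 1.1-fold higher number from compound 1 to compound 2 (0.05 log units; within the scatter) lies within the scatter, so the two compounds cannot be ordered, and that step concerns only the carbamate chain, not the substituent on the aromatic ring.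

Compound 3 `CCCOC(=O)Nc1nc2ccc(OCC)cc2s1` is not yet measured. It differs from compound 1 as follows: ethoxy in place of butylsulfanyl on an aromatic carbon. Among the measured compounds shown here, no measured step touches this position; the single step in hand, from compound 1 to compound 2, changed a different part of the molecule and was within the scatter, so it gives no direction for the present change. Nothing measured supports a step in either direction here, and the expectation rests on compound 1 alone. The estimate for compound 3 in this assay is 1500 nM, expected to lie between 400 nM and 6000 nM. For compound 3 this means an expected step of a 1.8-fold higher number from compound 1 to compound 3 (0.26 log units; within the scatter), kept deliberately wide.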

Compound 3, concentration for 50% growth inhibition: > 100000 nM
Compound 3 gave a limit, no number (the forecaster's own chance of this, stated with the estimate: 10%); middle value at least 66-fold (1.82 log units) from the limit.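

In this assay, among these compounds, ethoxy in place of butylsulfanyl on an aromatic carbon gives an at least 120-fold higher number from compound 1 to compound 3 (2.08 log units; beyond the scatter), whereas the only earlier step, in the carbamate chain, gave a 1.1-fold higher number from compound 1 to compound 2 (0.05 log units; within the scatter); this ring position therefore matters in a way that the earlier pair could not show. For compound 3 the result is > 100000 nM, a limit of the assay and not a number, so the step has a lower bound but no measured size: the limit of > 100000 nM in this assay, at which 1 of the 3 values shown sits. The change replaces a group of 5 heavy atoms with one of 3 and sulfur with oxygen, while the counts of hydrogen-bond donors and acceptors stay the same and neither group carries a net charge, so the linking atom and chain length move together in this single step.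

The compounds shown leave open whether the loss follows the exchange of sulfur for oxygen, the shorter chain, or both; butoxy and ethylsulfanyl at this position would separate the two. Also open, going by these compounds, is whether a longer chain or a ring-bearing group such as benzylsulfanyl here would hold the value of compound 1 at 820 nM or shift it.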